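Compound 4: acetyl in place of trifluoromethyl

The source may hold more compounds than are shown below. What is called first, only, known or untested is meant among the compounds shown, and "the series" means these compounds.

Compound 1 `O=C(CCc1cccc2c1B(O)OC2)Nc1cccc(-c2ccccc2)c1`: 12000 nM
Compound 2 `O=C(CCc1cccc2c1B(O)OC2)Nc1cccc(-c2ccc(F)cc2)c1`: 4100 nM
Compound 3 `O=C(CCc1cccc2c1B(O)OC2)Nc1cccc(-c2cccc(C(F)(F)F)c2)c1`: 23000 nM

These values come from an ADME assay on WI-38 cells (Homo sapiens) for cytotoxicity, read by MTT assay, with a stated time of 72 h; a higher number here means a weaker inhibitor, a lower number a stronger inhibitor. Two steps fix the place of compound 3 among them: a 1.9-fold higher number from compound 1 to compound 3 (0.28 log units; within the scatter), and a 5.6-fold higher number from compound 2 to compound 3 (0.75 log units; beyond the scatter). It therefore cannot be told apart from compound 1, while compound 2 stands clearly lower.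

Compound 4 `CC(=O)c1cccc(-c2cccc(NC(=O)CCc3cccc4c3B(O)OC4)c2)c1` has not yet been measured. It carries acetyl in place of trifluoromethyl on an aromatic carbon, meta to a large group: acetyl in place of trifluoromethyl on an aromatic carbon.

Among the measured compounds shown here, no measured compound carries acetyl, so the evidence is indirect. Two steps add a group to compound 1: a 2.9-fold lower number from compound 1 to compound 2 (0.47 log units; beyond the scatter) with fluoro, and the trifluoromethyl step already given. Both are small to modest, and the widest gap in the set is the modest one between compound 2 and compound 3. A large move is therefore not expected. Compound 1, with no added group, gives 12000 nM, and compound 4 is expected to lie near that value.

The estimated change is a 1.8-fold lower number from compound 3 to compound 4 (0.25 log units; within the scatter), a small step towards a lower number. For compound 4 the estimated value is 13000 nM, with an expected range from 5000 nM to 32000 nM.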

Compound 4, half-maximal inhibitory concentration: 2200 nM
Compound 4: middle estimate off by 5.9-fold (0.77 log units), on the high side; the whole stated range lies above it.
By their numbers in this assay, from the lowest: compounds 4 and 2 (each within the scatter of the next); then compounds 1 and 3 (each within the scatter of the next).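

In this assay, the exchange of trifluoromethyl for acetyl on this aromatic carbon, meta to a large group, gives a 10-fold lower number from compound 3 to compound 4 (1.02 log units; beyond the scatter), the largest step among these compounds, so the identity of the group at this place can matter a great deal. Compared with the compound carrying only hydrogen there, acetyl gives a 5.5-fold lower number from compound 1 to compound 4 (0.74 log units; beyond the scatter), a change beyond the scatter that trifluoromethyl at the same place did not produce, and the step of a 1.9-fold lower number from compound 2 to compound 4 (0.27 log units; within the scatter) shows that this value cannot be told apart from that of the compound bearing 4-fluorophenyl instead of 3-acetylphenyl. Nothing measured alongside these values accounts for the difference between acetyl and trifluoromethyl.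

The compounds shown leave open whether a carbonyl group is what matters here, since a single acetyl compound cannot separate it from other features, and a carboxylic acid, an amine or a longer ketone such as propanoyl at the same aromatic carbon would test this. They also leave open whether acetyl would give a similar step at another carbon of that ring.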